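The source may report more compounds than this note shows. Statements on the series, on what has been measured and on what is new or still open speak of the compounds shown alone.

In an ADME assay on HEK293 cells (Homo sapiens) for cytotoxicity, read by MTT assay, with a stated time of 36 h (a lower number here means a stronger inhibitor, a higher number a weaker inhibitor), the three measured compounds stand as follows.

Compound 1 `O=C(c1ccc2c(c1)OCCO2)C1CCN(Cc2coc(-c3ccc(Br)cc3)n2)CC1` gives > 150 ug/mL, which is a limit of the assay and not a number.
Compound 2 `O=C(c1ccc2c(c1)OCCO2)C1CCN(Cc2coc(-c3ccccc3)n2)CC1` gives > 150 ug/mL, again a limit.
Compound 3 `O=C(c1ccc2c(c1)OCCO2)C1CCN(Cc2coc(-c3ccc(F)c(F)c3)n2)CC1` gives > 150 ug/mL, also a limit.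

Compound 3 therefore has only a limit in this assay, and the two other values are limits too: all three sit at the limit of > 150 ug/mL in this assay, at which 3 of the 3 values shown sit. The steps among them, a step that the two limits leave unreadable from compound 1 to compound 2, a step that the two limits leave unreadable from compound 1 to compound 3 and a step that the two limits leave unreadable from compound 2 to compound 3, cannot be read in size or direction for that reason. The new compound 4 `O=C(c1ccc2c(c1)OCCO2)C1CCN(Cc2coc(-c3cccnc3)n2)CC1` differs from compound 3 by pyridin-3-yl in place of 3,4-difluorophenyl on an aromatic carbon. Within the data shown here, none of the measured steps gives a readable size, so no step beyond the scatter can be expected for this change either; the expected step that the limit leaves unreadable from compound 3 to compound 4 is simply that compound 4 also stays at the limit. Compound 4 is thus estimated at 200 ug/mL, with a range from 100 ug/mL to 400 ug/mL.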

Compound 4, half-maximal inhibitory concentration: > 150 ug/mL
Compound 4 gave a limit, no number; the forecaster's own chance of this, stated with the estimate: 85%; the middle value is on the limit's open side.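

In this assay compound 4 gives > 150 ug/mL, which is a limit and not a number. Its steps from compound 1, compound 2 and compound 3 therefore cannot be read, and all four compounds sit together: the limit of > 150 ug/mL in this assay, at which 4 of the 4 values shown sit. The compounds shown leave open where each true value lies and whether exchanging these aromatic groups changes it at all.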